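Cyano on the pyrazole ring, carried onto a second core

The source may report more compounds than this note shows. Statements on the series, on what has been measured and on what is new or still open speak of the compounds shown alone.

Measured so far in an assay on membranes from brain for binding affinity to Monoglyceride lipase (Mus musculus), read by fluorescence, with stated times of 1 h and 30 min; on this read-out lower numbers stand for stronger inhibition and higher numbers for weaker inhibition:
compound 1, `O=C(N1CCCN(Cc2ccc(OCc3ccccc3)cc2)CC1)n1cccn1`, gives 10000 nM
compound 2, `N#Cc1cnn(C(=O)N2CCCN(Cc3ccc(OCc4ccccc4)cc3)CC2)c1`, gives 10000 nM
compound 3, `O=C(N1CCN(C(c2ccc3ccccc3c2)c2ccc3ccccc3c2)CC1)n1cccn1`, gives 1800 nM

Compound 1 and compound 2 share one core and differ only in cyano in place of hydrogen on an aromatic carbon. In this assay the step of no change at the digits printed from compound 1 to compound 2 (within the scatter) was observed, so on that core the added nitrile brought no measurable gain.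

Compound 3 carries a different core; how the core of compound 3 differs from the core of compound 1 is not broken down here. Within this assay compound 3 stands lowest of the three numbers, and its distance to compound 1 and to compound 2 lies beyond the scatter in both cases.

Compound 4, `N#Cc1cnn(C(=O)N2CCN(C(c3ccc4ccccc4c3)c3ccc4ccccc4c3)CC2)c1`, has not yet been measured. It relates to compound 3 as compound 2 relates to compound 1: the change is cyano in place of hydrogen on an aromatic carbon. The surroundings of the changed atom, as described for both pairs, are the same word for word, so this is the same change set on the core of compound 3.

With one prior example only, the expectation rests on the step of no change at the digits printed from compound 1 to compound 2 (within the scatter) seen for compound 1 and compound 2, and the step from compound 3 to compound 4 is expected to be a 1.1-fold lower number from compound 3 to compound 4 (0.05 log units; within the scatter) in this assay. As far as these compounds go, whether the second core answers the nitrile the same way is unknown, which widens the range. Compound 4 is therefore estimated at 1600 nM in this assay, expected to fall between 500 nM and 5000 nM.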

Compound 4, half-maximal inhibitory concentration: 8 nM
Estimate against measurement, compound 4: 200-fold (2.30 log units) above, and the stated range ends above it.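

On the core of compound 3, the exchange of 1H-pyrazol-1-yl for 4-cyano-1H-pyrazol-1-yl gives, in this assay, a 230-fold lower number from compound 3 to compound 4 (2.35 log units; beyond the scatter), so here the nitrile brings much stronger inhibition. A step measured on one core therefore does not predict the size of the same step on the other core in this series: the same change on two cores in this assay, no change at the digits printed (within the scatter) from compound 1 to compound 2 and a 230-fold lower number (2.35 log units; beyond the scatter) from compound 3 to compound 4, 230-fold (2.35 log units) apart, beyond the scatter of two such steps. The two steps show that the outcome of this change depends on the core it is placed on, but they do not show which part of the core is responsible or why, and two cores give no rule for how a third would respond.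

As far as these compounds go, at this place on the pyrazole ring, only hydrogen and cyano are represented, so it remains open whether a chlorine atom, a methyl group or a carboxylic acid would give a step like the nitrile's on the core of compound 3. Also open is which of the differences between the core of compound 1 and the core of compound 3 governs the response, as these two cores differ in more than one place and no intermediate core is shown.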